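The source may report more compounds than this note shows. Statements on the series, on what has been measured and on what is new or still open speak of the compounds shown alone.

Measured so far:
compound 1 `CCC(C)C(C)/N=C(\NC#N)Nc1ccncc1` – 8 mg/kg
compound 2 `CC(/N=C(\NC#N)Nc1ccncc1)C1CC1` – 3 mg/kg
compound 3 `N#CN/C(=N\C1CCCCC1)Nc1ccncc1` – 20 mg/kg

In a functional assay on the whole organism (blood, strain Wistar-Okamoto) with Rattus norvegicus as the target, with a stated time of 5 days (a higher number here means that more compound is needed for the effect, a lower number that less compound is needed), compound 3 gives the highest of the three numbers; compound 1 lies nearest, compound 2 furthest. Compound 4 `CCC(C)(CC)/N=C(\NC#N)Nc1ccncc1` differs from compound 3 in one place: 1-ethyl-1-methylpropyl in place of cyclohexyl on a double-bonded nitrogen. Within the data shown here, two measured steps bear on this, both ending in cyclohexyl on the same nitrogen: a 2.5-fold higher number from compound 1 to compound 3 (0.40 log units; beyond the scatter) and a 6.7-fold higher number from compound 2 to compound 3 (0.82 log units; beyond the scatter). Both times the ring gave the higher number, so going back from cyclohexyl to a branched open chain is expected to lower it again. A modest step downward is therefore expected, a 2.5-fold lower number from compound 3 to compound 4 (0.40 log units; beyond the scatter), of roughly the size seen from compound 1. Compound 4 is estimated at 8 mg/kg, within 3 mg/kg to 25 mg/kg.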

Compound 4, minimum effective dose: 0.5 mg/kg
Compound 4: the middle estimate sits 16-fold (1.20 log units) above what was measured; the measured number lies below the stated range.
By their numbers in this assay, from the lowest: compound 4; then compound 2; then compound 1; then compound 3.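

In this assay, swapping the ring for an open chain with the same count of carbons gives a large change (a 40-fold lower number from compound 3 to compound 4 (1.60 log units; beyond the scatter)), so at this double-bonded nitrogen the arrangement of those carbons matters, not only their number. The 1-ethyl-1-methylpropyl group also gives a lower number than the two other branched groups (a 16-fold lower number from compound 1 to compound 4 (1.20 log units; beyond the scatter) and a 6.0-fold lower number from compound 2 to compound 4 (0.78 log units; beyond the scatter)), which puts compound 4 lowest of the four. No measurement here bears on why this happens.

On these data alone, it remains open whether a smaller tert-butyl group at this nitrogen would keep the low number. As far as these compounds go, it is equally open whether a hydroxyl on the 1-ethyl-1-methylpropyl chain would be tolerated.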